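Cyano in Place of Allyl: Expected Cytotoxicity of Compound 3

The source may hold more compounds than are shown below. What is called first, only, known or untested is meant among the compounds shown, and "the series" means these compounds.

Compound 1 `CO[C@]1(CO)S[C@@H](n2cc(C)c(=O)[nH]c2=O)C[C@@H]1O`: in an ADME assay on M8166 cells (Homo sapiens) for cytotoxicity, read by MTT assay, with a stated time of 4 days (on this read-out lower numbers stand for higher toxicity in this test and higher numbers for lower toxicity in this test), compound 1 gives > 100000 nM, a limit of the assay and not a number.
Compound 2 `C=CC[C@]1(CO)S[C@@H](n2cc(C)c(=O)[nH]c2=O)C[C@@H]1O`: in this assay compound 2 gives > 100000 nM, again a limit of the assay and not a number.

Compound 2 stands where every number shown stands, at the limit of > 100000 nM in this assay, at which 2 of the 2 values shown sit. Among the compounds with values here, the one measured step, a step that the two limits leave unreadable from compound 1 to compound 2, has a limit at each end, and its size is not readable. Compound 3 `Cc1cn([C@H]2C[C@H](O)[C@@](C#N)(CO)S2)c(=O)[nH]c1=O` differs from compound 2 by cyano in place of allyl on a saturated ring carbon. Within the data shown here, no measured step covers a cyano group, and the only step available says nothing about size, so the expectation for compound 3 rests on compound 2 alone, whose value in this assay is a limit. On that basis compound 3 is expected to give no more than the same limit, with a number no higher from compound 2 to compound 3 (the limit leaves the size open) expected to stay within the scatter. Compound 3 is therefore estimated at 100000 nM, in a range from 30000 nM to 300000 nM, with a real number below the limit possible but not expected.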

Compound 3, half-maximal cytotoxic concentration: > 10000 nM
Compound 3: no number, only a limit (the forecaster's own chance of this, stated with the estimate: 75%); the middle value does not contradict the limit.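

In this assay compound 3 gives > 10000 nM, a limit of the assay and not a number. Within the data shown here, compound 1, compound 2 and compound 3 all stand at limits, and no step between them can be read. The compounds shown leave open where the real cytotoxic concentration of each lies, and whether methoxy, allyl or cyano on this saturated ring carbon makes any difference in this assay.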